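Adding a methoxy to compound 1

The source may report more compounds than this note shows. Statements on the series, on what has been measured and on what is new or still open speak of the compounds shown alone.

Compound 1 `O=C(O)c1c(O)cccc1CCc1ccc2ccccc2c1` gives the limit > 100000 nM
Compound 2 `Cc1cc(O)c(C(=O)O)c(C=Cc2ccc3ccccc3c2)c1` gives 52000 nM
Compound 3 `CCN(CC)C(=O)c1c(/C=C/c2ccc3ccccc3c2)cc(OC)cc1OC` gives the limit > 100000 nM

These three readings come from an ADME assay on HEK293 cells (Homo sapiens) for cytotoxicity, read by resazurin assay, with a stated time of 24 h (on this read-out lower numbers stand for higher toxicity in this test and higher numbers for lower toxicity in this test), and two of them are limits of the assay, not numbers. Compound 1 stands at the limit of > 100000 nM in this assay, at which 2 of the 3 values shown sit, so its true position is not known as a number. Only compound 2 returns a number (52000 nM) in this set.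

The next compound to be tested is compound 4 `COc1cc(O)c(C(=O)O)c(CCc2ccc3ccccc3c2)c1`, which keeps the core of compound 1 and changes it in one place. It has methoxy in place of hydrogen on an aromatic carbon, para to a carboxy group, meta to a hydroxy group and meta to a large group: methoxy in place of hydrogen on an aromatic carbon.

Within the data shown here, no measured pair shows the size of this change directly. Among the measured compounds shown here, with compound 2 (52000 nM) as the only number to go by, a small step toward lower numbers in this assay is expected, possibly none beyond the scatter. The expected change is an at least 1.1-fold lower number from compound 1 to compound 4 (0.04 log units; that floor lies within the scatter), and it remains an estimate. A reading at the limit again would be no surprise. For compound 4 the estimated value is 90000 nM, with an expected range from 40000 nM to 160000 nM.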

Compound 4, half-maximal cytotoxic concentration: 65000 nM
The estimate for compound 4 lay 1.4-fold (0.14 log units) above the measured number, and the stated range covers the measured number.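

In this assay, compound 4 returns a number where compound 1 returns only a limit, so this aromatic carbon, para to a carboxy group and meta to a hydroxy group, is a place where a substitution can bring the reading within the measurable range. Methoxy in place of hydrogen there gives an at least 1.5-fold lower number from compound 1 to compound 4 (0.18 log units; that floor lies within the scatter), which fixes a lower bound on the size of the change and no more, and that bound alone does not separate the change from ordinary repeat variation. The true size of the step stays unknown because compound 1 sits at a limit of the assay and has no numerical value: the limit of > 100000 nM in this assay, at which 2 of the 4 values shown sit.

The compounds shown leave open whether this reading is particular to methoxy or would also appear with another group on the same carbon, such as a fluorine atom, an amine or a longer alkoxy chain. They also leave open whether methoxy on a different aromatic carbon of the core of compound 1 would give a comparable reading in this assay.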